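This account rests on a few compounds, and the source may have more. Where it says the series, first, only, none or still open, it means among the compounds named here.

Measured so far:
- compound 1, `CCc1ccc2[nH]c(=O)c(CN(Cc3ccc(F)cc3)Cc3ccc4ccccc4c3)cc2c1`: > 5000 nM in a toxicity assay on MDCK cells (Canis lupus familiaris) for cytotoxicity, read by crystal violet staining, with a stated time of 48 h; a lower number here means that less compound is tolerated, a higher number that more compound is tolerated
- compound 2, `Cc1ccc2[nH]c(=O)c(CN(Cc3cccc(F)c3)Cc3ccc4ccccc4c3)cc2c1`: > 5000 nM in this assay

Both results are limits of this assay, not numbers. Compound 1 is tolerated up to the limit > 5000 nM. Compound 2 likewise shows only the limit > 5000 nM. So compound 2 stands where every value of the set stands, at the limit of > 5000 nM in this assay, at which 2 of the 2 values shown sit; no ordering among the two compounds can be read from this.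

The next compound, compound 3, `CCc1ccc2[nH]c(=O)c(CN(Cc3cccc(F)c3)Cc3ccc4ccccc4c3)cc2c1`, differs from compound 2 by methyl in place of hydrogen on a saturated chain carbon bound to an aromatic carbon; cut one bond further out the same change reads methyl to ethyl. Compound 1 already carries the ethyl on its core and also sits at the limit.

Going by the values given here, no measured step exists for this change. The step that the limit leaves unreadable from compound 2 to compound 3 is expected to be none beyond the scatter. Compound 3 is therefore expected to give about 8000 nM, with a range from 4000 nM to 20000 nM, most probably again reported only as a limit.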

Compound 3, half-maximal cytotoxic concentration: > 5000 nM
Compound 3 gave a limit, no number; the forecaster's own chance of this, stated with the estimate: 85%; the middle value does not contradict the limit.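

Compound 3, like compound 1 and compound 2, gives only a limit in this assay, so no step among the three can be read: the limit of > 5000 nM in this assay, at which 3 of the 3 values shown sit.

The compounds shown leave open whether methyl in place of hydrogen, or 3-fluorophenyl in place of 4-fluorophenyl, changes the half-maximal cytotoxic concentration at all.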